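Methyl on the Aromatic Ring: A Second Test of a Small Step

This account rests on a few compounds, and the source may have more. Where it says the series, first, only, none or still open, it means among the compounds named here.

Measured compounds:
compound 1, `COc1ccc(Cn2c3c(c4ccccc4c2=O)CCOc2ccccc2-3)cc1` — 4490 nM
compound 2, `COc1ccc(Cn2c3c(c4ccc(C)cc4c2=O)CCOc2ccccc2-3)cc1` — 4400 nM
compound 3, `COCOc1ccccc1-c1cc2ccccc2c(=O)n1C` — 59500 nM

Compounds 1, 2 and 3 were tested in a functional assay on HL-60 cells (Homo sapiens) for cytotoxicity, read by sulforhodamine B assay; a lower number here means a stronger inhibitor, a higher number a weaker inhibitor. Compound 3 gives the highest number of the three; how its core differs from the core of compound 1 is not broken down here. Compound 2 differs from compound 1 by methyl in place of hydrogen on an aromatic carbon, and the step was a 1.0-fold lower number from compound 1 to compound 2 (0.01 log units; within the scatter). Compound 4, `COCOc1ccccc1-c1cc2cc(C)ccc2c(=O)n1C`, differs from compound 3 by methyl in place of hydrogen on an aromatic carbon. This is the same kind of change, though in compound 3 the ring sits in a fused or bridged system of two rings rather than four. Because the step of a 1.0-fold lower number from compound 1 to compound 2 (0.01 log units; within the scatter) stayed within the scatter, compound 4 is expected to show about a 1.0-fold lower number from compound 3 to compound 4 (0.01 log units; within the scatter). Compound 4 is therefore estimated at 58000 nM, between 25000 nM and 135000 nM.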

Compound 4, half-maximal inhibitory concentration: 14300 nM
Compound 4: the middle estimate sits 4.1-fold (0.61 log units) above what was measured; measured number below the stated range.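

In this assay, methyl in place of hydrogen on an aromatic carbon gave a 4.2-fold lower number from compound 3 to compound 4 (0.62 log units; beyond the scatter), and the same change did not have the same size on the two cores: the same change on two cores in this assay, a 1.0-fold lower number (0.01 log units; within the scatter) from compound 1 to compound 2 and a 4.2-fold lower number (0.62 log units; beyond the scatter) from compound 3 to compound 4, 4.1-fold (0.61 log units) apart, beyond the scatter of two such steps

The size of the step seen on the core of compound 1 therefore cannot simply be carried over to the core of compound 3. Within the data shown here, with one pair on each core, this shows only that the step can differ between cores; it does not show what sets the difference, nor does it give a rule for other cores.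

The compounds shown leave open whether a chlorine atom or an amine at that aromatic carbon would differ between the two cores in the same way. They also leave open how methyl would behave on another aromatic carbon.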